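A few compounds are considered here, and "the series" means these few. Any claim that something is new, unique, unknown or untested is made for them only; others in the source may bear on it.

Measured compounds in an assay on VSM-A10 cells for antagonist activity at Endothelin-1 receptor (Rattus norvegicus); a higher number here means a weaker inhibitor, a lower number a stronger inhibitor: compound 1 `CCCCCNc1cccc2c(S(=O)(=O)Nc3onc(C)c3C)cccc12` gives 80 nM; compound 2 `Cc1noc(NS(=O)(=O)c2cccc3c(NCCCCCc4ccccc4)cccc23)c1C` gives 3050 nM; compound 3 `Cc1noc(NS(=O)(=O)c2cccc3c(N4CCCCC4=O)cccc23)c1C` gives 270 nM.

Compound 3 stands second of the three, with a higher number than compound 1 and a lower number than compound 2. Compound 4 `Cc1noc(NS(=O)(=O)c2cccc3c(CN(C)C)cccc23)c1C` differs from it at one place: (dimethylamino)methyl in place of 2-oxopiperidin-1-yl on an aromatic carbon. Within the data shown here, no measured step covers this change. The two known steps both replace groups on the same aromatic carbon of the shared core, a 3.4-fold higher number from compound 1 to compound 3 (0.53 log units; beyond the scatter) and a 38-fold higher number from compound 1 to compound 2 (1.58 log units; beyond the scatter), each toward weaker inhibition. Among the measured compounds shown here, the (dimethylamino)methyl group appears in no measured compound, so the expected step of a 2.2-fold higher number from compound 3 to compound 4 (0.35 log units; beyond the scatter) rests only on the modest loss seen in this assay for the other substitution at that carbon. Compound 4 is therefore estimated at 600 nM, with a range from 150 nM to 2500 nM.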

Compound 4, half-maximal inhibitory concentration: 2800 nM
For compound 4 the middle estimate is 4.7-fold (0.67 log units) below the measured one; measured number above the stated range.
By their numbers in this assay, from the lowest: compound 1; then compound 3; then compounds 4 and 2 (each within the scatter of the next).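

In this assay, the step of a 10-fold higher number from compound 3 to compound 4 (1.02 log units; beyond the scatter) shows that a group with fewer heavy atoms and no ring can still cost much at this aromatic carbon. The step of a 35-fold higher number from compound 1 to compound 4 (1.54 log units; beyond the scatter) places compound 4 within the scatter of compound 2, so a large loss here does not require a phenyl-ended chain. Nothing available explains this loss.

The compounds shown leave open whether the methylene link or the amine matters more. A dimethylamino group directly on that carbon, or a hexyl chain, would help separate these.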